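Two Halogens, Two Alkyl Chains, One Weakly Cytotoxic Core

This account rests on a few compounds, and the source may have more. Where it says the series, first, only, none or still open, it means among the compounds named here.

Measured so far:
compound 1, `CCn1c(/C=C2/C(=O)Nc3ccc(Br)cc32)nc2ccccc21`: 40700 nM
compound 2, `Cn1c(/C=C2/C(=O)Nc3ccc(Br)cc32)nc2ccccc21`: > 50000 nM
compound 3, `Cn1c(/C=C2/C(=O)Nc3ccc(Cl)cc32)nc2ccccc21`: 43600 nM

All three share one core and were tested in a functional assay on 4T1 cells (Homo sapiens) for cytotoxicity, read by MTT assay, with a stated time of 48 h (on this read-out lower numbers stand for stronger inhibition and higher numbers for weaker inhibition), where compound 1 gives 40700 nM and compound 3 gives 43600 nM. For compound 2 the assay reports only (the limit of > 50000 nM in this assay, at which 1 of the 3 values shown sits), which is a limit and not a number. The whole set therefore sits at weak inhibition.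

Compound 2 and compound 1 differ by methyl in place of hydrogen on a saturated chain carbon bound to an aromatic nitrogen, and that change brings an at least 1.2-fold lower number from compound 2 to compound 1 (0.08 log units; that floor lies within the scatter). Compound 2 and compound 3 differ by chloro in place of bromo on an aromatic carbon, which brings an at least 1.1-fold lower number from compound 2 to compound 3 (0.05 log units; that floor lies within the scatter). Compound 1 and compound 3 lie within the scatter of each other, so their two numbers show no separation.

Compound 4, `CCn1c(/C=C2/C(=O)Nc3ccc(Cl)cc32)nc2ccccc21`, has not yet been measured. It differs from compound 3 by methyl in place of hydrogen on a saturated chain carbon bound to an aromatic nitrogen, the same change that separates compound 2 from compound 1, at the same place. Because that earlier step gave an at least 1.2-fold lower number from compound 2 to compound 1 (0.08 log units; that floor lies within the scatter), only a small step is expected here as well, and compound 4 is estimated to show a 1.2-fold lower number from compound 3 to compound 4 (0.10 log units; within the scatter). On this basis compound 4 is expected to give about 35000 nM, most likely between 15000 nM and 80000 nM.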

Compound 4, half-maximal inhibitory concentration: > 50000 nM
Compound 4 ended at the assay's limit; the forecaster's own chance of this, stated with the estimate: 25%; middle value at least 1.4-fold (0.15 log units) away from the limit.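

In this assay compound 4 gives > 50000 nM, which is a limit of the assay and not a number. Changing methyl to ethyl on the chloro compounds gives an at least 1.1-fold higher number from compound 3 to compound 4 (0.05 log units; that floor lies within the scatter), so the data neither show that this change carries over from the bromo compounds nor show that it fails to: the same change on two cores in this assay, an at least 1.2-fold lower number (0.08 log units; that floor lies within the scatter) from compound 2 to compound 1 and an at least 1.1-fold higher number (0.05 log units; that floor lies within the scatter) from compound 3 to compound 4; the limit leaves it open whether they differ. Putting chloro in place of bromo on the ethyl compounds gives an at least 1.2-fold higher number from compound 1 to compound 4 (0.08 log units; that floor lies within the scatter), and this swap likewise cannot be said to behave the same way or a different way on the two chains: the same change on two cores in this assay, an at least 1.1-fold lower number (0.05 log units; that floor lies within the scatter) from compound 2 to compound 3 and an at least 1.2-fold higher number (0.08 log units; that floor lies within the scatter) from compound 1 to compound 4; the limit leaves it open whether they differ.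

The compounds shown leave open whether a longer chain such as propyl, or a chain ending in an amine or a carboxylic acid, would shift the number by more than the scatter. They also leave open what fluoro or methoxy would do in place of the bromo or chloro group, since only these two halogens and these two short chains appear here.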